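The source may report more compounds than this note shows. Statements on the series, on what has been measured and on what is new or still open speak of the compounds shown alone.

Measured so far:
Compound 1, `CNCc1cc(-c2cccnc2F)n(S(=O)(=O)c2ccsc2)c1`, gives 29 ng.h/mL in an ADME assay on the whole organism (plasma, Rattus norvegicus, strain Sprague-Dawley) for pharmacokinetics, read by LC-MS, using cassette dosing, at a dose of 0.2 mg/kg by the intravenous route; a lower number here means less compound in the circulation, a higher number more compound in the circulation at the dose given.
Compound 2, `CNCc1cn(S(=O)(=O)c2ccccn2)c(-c2cccnc2F)c1F`, gives 33 ng.h/mL in this assay.

Of the compounds shown here, two have been measured. Among the compounds with values here, compound 2 gives the higher of the two numbers in this assay, but its value and that of compound 1 lie within the scatter of each other, so the two cannot be told apart on these data, and no step between them is known.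

Compound 3, `CNCc1cn(S(=O)(=O)c2ccc(F)cn2)c(-c2cccnc2F)c1F`, has not yet been measured. It differs from compound 2 in one place: fluoro in place of hydrogen on an aromatic carbon. A fluorine atom enters where a hydrogen atom stood, on an aromatic carbon of a six-membered aromatic ring with 1 nitrogen, so that the pyridin-2-yl group becomes a 5-fluoropyridin-2-yl group.

Within the data shown here, no measured pair shows what such a change does here, so the expectation rests on the size of the change alone: a single fluorine entering. The step expected in this assay is a 1.1-fold higher number from compound 2 to compound 3 (0.03 log units; within the scatter), with no clear direction beyond the scatter. Compound 3 is therefore estimated at 35 ng.h/mL, with a range from 15 ng.h/mL to 80 ng.h/mL.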

Compound 3, area under the concentration-time curve: 22 ng.h/mL
Beside the measured number, compound 3's estimate is 1.6-fold (0.20 log units) above it, within the range that was stated.
By their numbers in this assay, from the lowest: compounds 3, 1 and 2 (each within the scatter of the next).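

Within the data shown here, this is the first measured pair that isolates a single change, so it gives the first direct reading of this position on the pyridin-2-yl group, two atoms from the ring nitrogen and para to a large group. Replacing hydrogen with fluoro to give the 5-fluoropyridin-2-yl group produces a 1.5-fold lower number from compound 2 to compound 3 (0.18 log units; within the scatter) in this assay, a step that lies within the usual scatter, so compound 2 and compound 3 cannot be told apart and this single atom leaves no clear mark on the read-out in this pair. No separate measurement at hand bears on what lies behind these numbers.

Whether a chloro group, a methoxy group or an amine at this same position would give a step beyond the scatter remains open, as fluoro is the only replacement of hydrogen shown here. From the compounds shown here alone, it is also open whether fluoro at this position would give a similar result with other groups elsewhere on the molecule, as this reading rests on one pair alone.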